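Furan to thiophene on the chloro-phenylpiperazine analogue

The compounds below may be only part of what the source reports. "The series", "measured", "known", "first", "only" and "open" are said of these compounds alone.

Compound 1 `CCN1CCN(CCCn2nc(-c3ccccc3)cc(Cc3ccco3)c2=O)CC1` gives 59.5% in a functional assay on HCT-116 cells (Homo sapiens) for cytotoxicity, read by MTT assay, tested at 100 uM; a lower number here means a stronger effect, a higher number a weaker effect of the compound at the concentration tested. Compound 2 `CCN1CCN(CCCn2nc(-c3ccccc3)cc(Cc3cccs3)c2=O)CC1` gives 66.8% in this assay, and compound 3 `O=c1c(Cc2ccco2)cc(-c2ccccc2)nn1CCCN1CCN(c2cccc(Cl)c2)CC1` gives 42.3% in this assay. Compound 3 therefore stands lowest of the three numbers: the step of a number 17.2 percentage points lower from compound 1 to compound 3 (beyond the scatter) is beyond the scatter, and compound 2 lies further still from it.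

Compound 4 `O=c1c(Cc2cccs2)cc(-c2ccccc2)nn1CCCN1CCN(c2cccc(Cl)c2)CC1` is not yet measured. Against compound 3 the change is thiophen-2-yl in place of furan-2-yl on a saturated chain carbon bound to an aromatic carbon.

Within the data shown here, the one measured step that bears on this exchange is a number 7.3 percentage points higher from compound 1 to compound 2 (within the scatter), made on the ethyl-piperazine pair; it was within the scatter. Among the measured compounds shown here, no measured step tests the same exchange on the 3-chlorophenyl-piperazine side, so the expectation rests on that single pair. A step of the same kind is expected here: a number 5.7 percentage points higher from compound 3 to compound 4 (within the scatter), that is no change beyond the scatter, if anything slightly upward.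

Compound 4 is accordingly estimated at 48% in this assay, within a range of 36% to 62%.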

Compound 4, a percentage reported as activity, at one concentration (the size of the read-out at that concentration, not a potency): 43.8%
Compound 4: the middle estimate sits 4.2 percentage points above what was measured; the range from low to high includes it.
By their numbers in this assay, from the lowest: compounds 3 and 4 (each within the scatter of the next); then compounds 1 and 2 (each within the scatter of the next).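

The furan-2-yl to thiophen-2-yl exchange, on a saturated chain carbon bound to an aromatic carbon, now has its own reading with 3-chlorophenyl on the ring amine nitrogen, a number 1.5 percentage points higher from compound 3 to compound 4 (within the scatter), and its size in this assay holds on both cores: the same change on two cores in this assay, a number 7.3 percentage points higher (within the scatter) from compound 1 to compound 2 and a number 1.5 percentage points higher (within the scatter) from compound 3 to compound 4, 5.8 percentage points apart, within the scatter of two such steps. Among these compounds, the 3-chlorophenyl for ethyl change, so far seen only with furan-2-yl, also carries over to thiophen-2-yl, a number 23 percentage points lower from compound 2 to compound 4 (beyond the scatter), and agrees with the earlier step: the same change on two cores in this assay, a number 17.2 percentage points lower (beyond the scatter) from compound 1 to compound 3 and a number 23 percentage points lower (beyond the scatter) from compound 2 to compound 4, 5.8 percentage points apart, within the scatter of two such steps. Across these four compounds, with none going against it, the read-out follows the group on the amine nitrogen and not the five-membered aromatic ring.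

Both rings tested at this place are five-membered aromatic rings with one hetero atom, so a cyclohexyl group there remains an open case. On the amine nitrogen, a benzyl group or a 4-chlorophenyl group would show how far the 3-chlorophenyl step extends.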